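The source may report more compounds than this note shows. Statements on the series, on what has been measured and on what is new or still open speak of the compounds shown alone.

Of the compounds shown here, two from this series have been measured in a functional assay on B16-F10 cells (Mus musculus) for cytotoxicity, read by CCK-8 assay, with a stated time of 48 h; on this read-out lower numbers stand for stronger inhibition and higher numbers for weaker inhibition. Compound 1 `Cc1cc(C)nc(NS(=O)(=O)c2ccc(/N=C/c3c(Cl)c4ccccc4oc3=O)cc2)n1` carries a dimethylpyrimidinyl group on its sulfonamide nitrogen and no tert-butyl groups on the shared core; in this assay compound 1 gives 170 nM. Compound 2 `CC(C)(C)c1cc(C(C)(C)C)c2oc(=O)c(/C=N/c3ccc(S(N)(=O)=O)cc3)c(Cl)c2c1` has two tert-butyl groups on the core and a free sulfonamide; in this assay compound 2 gives 240 nM. Of the two numbers, that of compound 2 is the higher, but the gap to compound 1 lies within the scatter of repeated measurements, so the two compounds cannot be told apart on these data.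

Compound 3 `Cc1cc(NS(=O)(=O)c2ccc(/N=C/c3c(Cl)c4cc(C(C)(C)C)cc(C(C)(C)C)c4oc3=O)cc2)no1` keeps the core of compound 2 and differs from it in one place: 5-methyl-1,2-oxazol-3-yl in place of hydrogen on a sulfonamide nitrogen. Among the measured compounds shown here, no measured pair in this set isolates this change, so no computed step exists for it. Compound 1, which also carries an aromatic heterocycle on the sulfonamide nitrogen, sits close to compound 2, which leaves little ground for expecting a large move in either direction. The step expected from compound 2 to compound 3 is a 1.2-fold lower number from compound 2 to compound 3 (0.08 log units; within the scatter), a shift that stays within the scatter. Compound 3 is therefore estimated at 200 nM, with a likely range from 80 nM to 500 nM.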

Compound 3, half-maximal inhibitory concentration: 240 nM
Compound 3: the middle estimate sits 1.2-fold (0.08 log units) below what was measured, and the stated range covers the measured number.
By their numbers in this assay, from the lowest: compounds 1, 2 and 3 (each within the scatter of the next).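

With 5-methyl-1,2-oxazol-3-yl in place of hydrogen on a sulfonamide nitrogen, the result is no change at the digits printed from compound 2 to compound 3 (within the scatter) in this assay on the core bearing two tert-butyl groups. Among the compounds shown here, this is the first comparison that isolates this nitrogen, since compound 1 and compound 2 differ in more than one place and could not separate the sulfonamide substituent from the tert-butyl groups. On this core, then, the free sulfonamide and the sulfonamide carrying this aromatic ring cannot be told apart in this read-out, and the position accepts the substituent with no measurable penalty or gain. Nothing available explains why the number holds, and no separate measurement bears on it.

The compounds shown leave open whether a small methyl or acetyl group on that nitrogen, or a chain ending in an amine or a carboxylic acid, would behave in the same way. They also leave open whether the same 5-methyl-1,2-oxazol-3-yl change would give a similar result on a core without the tert-butyl groups.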